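The source may report more compounds than this note shows. Statements on the series, on what has been measured and on what is new or still open speak of the compounds shown alone.

Of the compounds shown here, three with a shared core have been tested in a functional assay on A549 cells (Homo sapiens) for antiproliferative activity, read by MTT assay, with a stated time of 72 h; on this read-out higher numbers stand for weaker inhibition and lower numbers for stronger inhibition. Compound 1 `CCC/C=C/C(=O)Nc1cccc(Oc2nc(Nc3cccc(C#N)c3)nc3c2CSCC3)c1` gives 5790 nM, compound 2 `CCC/C=C/C(=O)Nc1cccc(Oc2nc(Nc3ccc(OC)cc3)nc3c2CSCC3)c1` gives 11900 nM, and compound 3 `C/C=C/C(=O)Nc1cccc(Oc2nc(Nc3ccc(OC)nc3)nc3c2CSCC3)c1` gives 8040 nM. The value of compound 3 lies within the usual scatter of both other values, so it cannot be told apart from either of them.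

Compound 4 `CCC/C=C/C(=O)Nc1cccc(Oc2nc(Nc3ccc(OC)nc3)nc3c2CSCC3)c1` differs from compound 3 in one place: ethyl in place of hydrogen on a saturated chain carbon bound to a double-bonded chain carbon. This is ethyl in place of hydrogen on a saturated chain carbon bound to a double-bonded chain carbon, which turns prop-1-en-1-yl into pent-1-en-1-yl.

Among the measured compounds shown here, no measured step isolates this change. For the measured compounds named here, the only single-place step, a 2.1-fold higher number from compound 1 to compound 2 (0.31 log units; beyond the scatter), is modest and concerns 4-methoxyphenyl in place of 3-cyanophenyl on a nitrogen on an aromatic ring, so it bears on the change only indirectly, as a sign of how far these numbers move. Compound 2 already carries pent-1-en-1-yl, though it also differs from compound 3 on that nitrogen. Compound 2 gives 11900 nM and compound 3 gives 8040 nM, two values within the scatter of each other.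

The expected result is a 1.0-fold lower number from compound 3 to compound 4 (0.00 log units; within the scatter), which means no step beyond the scatter in this assay. The estimate for compound 4 is 8000 nM, with an expected range of 3500 nM to 18000 nM.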

Compound 4, half-maximal inhibitory concentration: 10800 nM
For compound 4 the middle estimate is 1.4-fold (0.13 log units) below the measured one; the range from low to high includes it.
By their numbers in this assay, from the lowest: compounds 1, 3, 4 and 2 (each within the scatter of the next, the first and the last beyond it).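

In this assay, among the compounds shown here, the exchange of prop-1-en-1-yl for pent-1-en-1-yl, now seen for the first time with everything else held fixed, gives a 1.3-fold higher number from compound 3 to compound 4 (0.13 log units; within the scatter) and so cannot be told apart from repeat-measurement noise at this position. With pent-1-en-1-yl kept in place, compound 4 also shows that 6-methoxypyridin-3-yl on the nitrogen cannot be separated from either earlier group: against 4-methoxyphenyl the result is a 1.1-fold lower number from compound 2 to compound 4 (0.04 log units; within the scatter) and against 3-cyanophenyl it is a 1.9-fold higher number from compound 1 to compound 4 (0.27 log units; within the scatter) even though the exchange between those two phenyl groups alone went just beyond the scatter. No supporting data on the compounds speak to what lies behind these small steps.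

As far as these compounds go, the ethyl change is seen as a single pair carrying 6-methoxypyridin-3-yl on the nitrogen, so whether it would read the same with 3-cyanophenyl or 4-methoxyphenyl there stays open. Also open, from the compounds shown here alone, is whether a longer chain such as hept-1-en-1-yl, or a chain ending in an amine, would move the number beyond the scatter in this assay at this position.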